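A few compounds are considered here, and "the series" means these few. Any claim that something is new, unique, unknown or untested is made for them only; others in the source may bear on it.

Among the compounds with values here, in a functional assay on A549 cells (Homo sapiens) for cytotoxicity, read by MTT assay, with a stated time of 24 h (on this read-out higher numbers stand for weaker inhibition and lower numbers for stronger inhibition), compound 1 `CN(C)CCN1CCN(CC(=O)Nc2ccc(-c3nc4cc(F)ccc4o3)cc2)CC1` gives 16600 nM, the second highest of the three numbers known. Within the data shown here, compound 2 `Cc1cc(-c2nc3cc(F)ccc3o2)ccc1NC(=O)CN1CCN(CCN(C)C)CC1` gives 7370 nM; the only one-place step known, a 2.3-fold lower number from compound 1 to compound 2 (0.35 log units; beyond the scatter), concerns a methyl in place of hydrogen on an aromatic carbon, a change at a different place than the one considered here. Compound 3 `CN(C)CCCN1CCN(CC(=O)Nc2ccc(-c3nc4ccccc4o3)cc2)CC1` gives 18300 nM, within the scatter of compound 1; it differs from compound 1 in more than one place, so only the two values can be set side by side. Compound 4 `CN(C)CCN1CCN(CC(=O)Nc2ccc(-c3nc4cc(Cl)ccc4o3)cc2)CC1` differs from compound 1 by chloro in place of fluoro on an aromatic carbon. Among the measured compounds shown here, no measured step bears on this change, so no step beyond the scatter is expected in this assay, in either direction. Compound 4 is therefore estimated at 14000 nM, with a range of 6000 nM to 32000 nM. The expected step is a 1.2-fold lower number from compound 1 to compound 4 (0.07 log units; within the scatter).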

Compound 4, half-maximal inhibitory concentration: 7100 nM
Compound 4: the middle estimate sits 2.0-fold (0.29 log units) above what was measured; low and high end bracket the measured number.
By their numbers in this assay, from the lowest: compounds 4 and 2 (each within the scatter of the next); then compounds 1 and 3 (each within the scatter of the next).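

In this assay, the halogen place on the six-membered aromatic ring of the fused system proves sensitive to the choice of halogen: a 2.3-fold lower number from compound 1 to compound 4 (0.37 log units; beyond the scatter). Within the data shown here, this is the first one-place step read at this position, and it shows that exchanging one single-atom halogen for another can move the number beyond the scatter. Nothing measured here accounts for the step.

On these data alone, whether bromo, trifluoromethyl or methoxy at this place would give a lower or higher number remains open. Also open, as far as these compounds go, is whether the chloro step holds alongside the methyl of compound 2 or on a longer chain.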